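Swapping a five-membered ring on a shared core

This account rests on a few compounds, and the source may have more. Where it says the series, first, only, none or still open, it means among the compounds named here.

Compound 1, `O=C(Nc1cc(Sc2ncn[nH]2)c(O)c2ccccc12)c1ccc([N+](=O)[O-])cc1`: 53500 nM
Compound 2, `O=C(Nc1cc(Sc2ncn[nH]2)c(O)c2ccccc12)c1cccc([N+](=O)[O-])c1`: 26900 nM
Compound 3, `O=C(Nc1cc(Sc2nncs2)c(O)c2ccccc12)c1ccc(Cl)cc1`: > 100000 nM

These values come from a functional assay on PC-3 cells (Homo sapiens) for antiproliferative activity, read by MTT assay, with a stated time of 48 h; on this read-out higher numbers stand for weaker inhibition and lower numbers for stronger inhibition. Among the measured compounds shown here, compound 1 and compound 2 both give measurable numbers, and the one step between them, a 2.0-fold lower number from compound 1 to compound 2 (0.30 log units; within the scatter), is within the scatter. For compound 3 this assay reports only a limit, (the limit of > 100000 nM in this assay, at which 1 of the 3 values shown sits). Compound 3 therefore has no number of its own to stand on; it sits at the edge of what this assay can report, with the two measured compounds as the only fixed points nearby.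

Compound 4, `O=C(Nc1cc(Sc2ncn[nH]2)c(O)c2ccccc12)c1ccc(Cl)cc1`, is compound 3 with a single change: 1H-1,2,4-triazol-5-yl in place of 1,3,4-thiadiazol-2-yl on a sulfur. For the measured compounds named here, no measured pair shows this change on its own, so no measured step sets its size or direction. What the data do show is that the two compounds carrying the entering ring, compound 1 and compound 2, give weak but measurable numbers in this assay, while compound 3, carrying the leaving ring, gives only a limit. The change is thus expected to move compound 4 at most modestly, and the expected step of an at least 1.4-fold lower number from compound 3 to compound 4 (0.15 log units; that floor lies within the scatter) is set against a limit, so its direction is uncertain. Compound 4 is expected to give about 70000 nM, between 25000 nM and 200000 nM, with a fair chance that this assay again returns only a limit.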

Compound 4, half-maximal inhibitory concentration: 5520 nM
For compound 4 the middle estimate is 13-fold (1.10 log units) above the measured one; measured number outside the range, below it.
By their numbers in this assay, from the lowest: compound 4; then compounds 2 and 1 (each within the scatter of the next). At a limit, above all of these: compound 3.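

In this assay, the ring swap on the sulfur brings an at least 18-fold lower number from compound 3 to compound 4 (1.25 log units; beyond the scatter), so the 1H-1,2,4-triazol-5-yl and 1,3,4-thiadiazol-2-yl rings are not interchangeable here, even though each is a five-membered aromatic ring with 3 hetero atoms. From the compounds shown here alone, that step is only a floor and its true size is unknown, because compound 3 has a limit rather than a number of its own: the limit of > 100000 nM in this assay, at which 1 of the 4 values shown sits. With the 1H-1,2,4-triazol-5-yl ring kept, the group on the carbonyl carbon also counts, as 4-chlorophenyl in place of 3-nitrophenyl brings a 4.9-fold lower number from compound 2 to compound 4 (0.69 log units; beyond the scatter), and chloro in place of nitro brings a 9.7-fold lower number from compound 1 to compound 4 (0.99 log units; beyond the scatter).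

Among the compounds shown here, the ring swap is seen only with the 4-chlorophenyl group, so whether it would have a similar effect with a nitrophenyl group on the carbonyl carbon remains open. It is also unknown how an amine or a carboxylic acid in place of the chloro would read in this assay.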